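This account rests on a few compounds, and the source may have more. Where it says the series, first, only, none or still open, it means among the compounds named here.

compound 1 `Nc1cc(N)c2nc(-c3ccccc3)c(Oc3ccc(Cl)c(Cl)c3)nc2c1`: < 100000 nM
compound 2 `CCOC(=O)[C@H](CCC(=O)O)NC(=O)c1ccc(Sc2nc3cc(N)cc(N)c3nc2-c2ccccc2)cc1`: < 100000 nM
compound 3 `CCOC(=O)[C@H](CCC(=O)O)NC(=O)c1ccc(Oc2nc3cc(N)cc(N)c3nc2-c2ccccc2)cc1`: 16600 nM

In a functional assay on SN12C cells (Homo sapiens) for inhibition, read by sulforhodamine B assay, with a stated time of 48 h (a higher number here means a weaker inhibitor of growth, a lower number a stronger inhibitor of growth), compound 1 gives only a limit, < 100000 nM, and no number. Compound 2 likewise stops at a limit, < 100000 nM. Compound 3 alone gives a number, 16600 nM. Compound 1 thus stands at the limit of < 100000 nM in this assay, at which 2 of the 3 values shown sit, so its place among the three cannot be fixed. Compound 4 `COc1ccc(Sc2nc3cc(N)cc(N)c3nc2-c2ccccc2)cc1` differs from compound 1 by (4-methoxyphenyl)sulfanyl in place of 3,4-dichlorophenoxy on an aromatic carbon. Among the measured compounds shown here, no measured pair shows this change, and compound 1 itself has no number, so no direction for the step in this assay can be read from the values shown, and a move beyond the usual scatter either way remains possible. Compound 4 is expected to give 30000 nM, between 5000 nM and 100000 nM. The expected step is a step that the limit leaves unreadable from compound 1 to compound 4, an estimate only.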

Compound 4, concentration for total growth inhibition: 24000 nM
Estimate against measurement, compound 4: 1.3-fold (0.10 log units) above; measured number inside the range.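

Compound 1 gives only a limit, < 100000 nM, in this assay, so no step from it to compound 4 can be read: the limit of < 100000 nM in this assay, at which 2 of the 4 values shown sit.

From the compounds shown here alone, whether (4-methoxyphenyl)sulfanyl in place of 3,4-dichlorophenoxy on an aromatic carbon strengthens or weakens growth inhibition therefore stays open.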